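Pyridinyl for Pyrimidinyl Sulfonamides in MCF7 Cytotoxicity

A few compounds are considered here, and "the series" means these few. Any claim that something is new, unique, unknown or untested is made for them only; others in the source may bear on it.

Compound 1 `O=c1c(CNc2ccc(S(=O)(=O)Nc3ccccn3)cc2)coc2ccccc12`: in a functional assay on MCF7 cells (Homo sapiens) for cytotoxicity, read by sulforhodamine B assay, with a stated time of 72 h (a higher number here means a weaker inhibitor, a lower number a stronger inhibitor), compound 1 gives > 100000 nM, a limit of the assay.
Compound 2 `O=c1c(CNc2ccc(S(=O)(=O)Nc3ncccn3)cc2)coc2ccccc12`: in this assay compound 2 gives > 100000 nM, a limit of the assay.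
Compound 3 `O=C1/C(=C/c2coc3ccccc3c2=O)N=C(c2ccccc2)N1c1ccc(S(=O)(=O)Nc2ncccn2)cc1`: in this assay compound 3 gives > 100000 nM, a limit of the assay.

Compound 2 and compound 1 differ in one place, (pyridin-2-yl in place of pyrimidin-2-yl on a sulfonamide nitrogen). The step that the two limits leave unreadable from compound 2 to compound 1 cannot be sized because of the limit of > 100000 nM in this assay, at which 3 of the 3 values shown sit. The difference between the core of compound 2 and the core of compound 3 is not broken down here. Compound 4 `O=C1/C(=C/c2coc3ccccc3c2=O)N=C(c2ccccc2)N1c1ccc(S(=O)(=O)Nc2ccccn2)cc1` has not yet been tested; it carries the same change relative to compound 3, (pyridin-2-yl in place of pyrimidin-2-yl on a sulfonamide nitrogen), at the same place. The same change left compound 1 and compound 2 both at the limit. Compound 4 is therefore expected to remain at the limit too, a step that the limit leaves unreadable from compound 3 to compound 4 that is an estimate only. The estimated value for compound 4 in this assay is 150000 nM, ranging from 50000 nM to 500000 nM.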

Compound 4, half-maximal inhibitory concentration: > 100000 nM
Compound 4: a limit, no number; the forecaster's own chance of this, stated with the estimate: 85%; the middle value is on the limit's open side.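

Compound 3 and compound 4 both sit at a limit of the assay, so no size can be read for the step between them: the limit of > 100000 nM in this assay, at which 4 of the 4 values shown sit.
The compounds shown leave open whether pyridin-2-yl in place of pyrimidin-2-yl changes potency in this assay at all.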